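Swapping the Amine on Compound 3

The compounds below may be only part of what the source reports. "The series", "measured", "known", "first", "only" and "open" are said of these compounds alone.

- Compound 1 `Cc1ccc(Cn2cc(/C=N/NC(=O)Nc3nc4ccc(CN5CCC(C)CC5)cc4s3)c3ccccc32)cc1` gives 1140 nM
- Compound 2 `CN(C)Cc1ccc2nc(NC(=O)N/N=C/c3cn(Cc4ccccc4)c4ccccc34)sc2c1` gives 1340 nM
- Compound 3 `CCN(CC)Cc1ccc2nc(NC(=O)N/N=C/c3cn(Cc4ccccc4)c4ccccc34)sc2c1` gives 1470 nM

These values come from a functional assay on MDA-MB-231 cells (Homo sapiens) for cytotoxicity, read by MTT assay, with a stated time of 72 h; on this read-out higher numbers stand for weaker inhibition and lower numbers for stronger inhibition. Compound 3 lies within the usual scatter of both other compounds, so the numbers set no order among them. The change 4-methylpiperidin-1-yl in place of diethylamino on a saturated chain carbon bound to an aromatic carbon puts 4-methylpiperidin-1-yl in place of diethylamino on a saturated chain carbon bound to an aromatic carbon, giving compound 4 `CC1CCN(Cc2ccc3nc(NC(=O)N/N=C/c4cn(Cc5ccccc5)c5ccccc45)sc3c2)CC1`. Among the measured compounds shown here, the only measured step at this place is a 1.1-fold higher number from compound 2 to compound 3 (0.04 log units; within the scatter). Compound 1, which also carries 4-methylpiperidin-1-yl but differs elsewhere, gives 1140 nM. No step beyond the scatter is therefore expected in this assay, in either direction. The expected step is a 1.1-fold lower number from compound 3 to compound 4 (0.05 log units; within the scatter). For compound 4 the estimated value is 1300 nM (expected range 700 nM to 2400 nM).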

Compound 4, half-maximal inhibitory concentration: 2850 nM
Beside the measured number, compound 4's estimate is 2.2-fold (0.34 log units) below it; the measured number lies above the stated range.
By their numbers in this assay, from the lowest: compounds 1, 2, 3 and 4 (each within the scatter of the next, the first and the last beyond it).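

In this assay, 4-methylpiperidin-1-yl in place of diethylamino gives a 1.9-fold higher number from compound 3 to compound 4 (0.29 log units; within the scatter), so these two groups cannot be told apart, but in place of dimethylamino it gives a 2.1-fold higher number from compound 2 to compound 4 (0.33 log units; beyond the scatter). Among the compounds shown here, that is the first step at this place to pass the scatter. A change elsewhere also passes it: hydrogen in place of methyl on an aromatic carbon gives a 2.5-fold higher number from compound 1 to compound 4 (0.40 log units; beyond the scatter).

As far as these compounds go, whether a morpholine on the same saturated chain carbon would sit nearer compound 2 or compound 4 stays open. Nothing measured here says why these steps arise.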